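This account rests on a few compounds, and the source may have more. Where it says the series, first, only, none or still open, it means among the compounds named here.

In a functional assay (ileum) with Cavia porcellus as the target (a lower number here means a stronger inhibitor, a higher number a weaker inhibitor), compound 1 `CCCCCCCC/N=C/N1CCC(C(c2ccccc2)c2ccccc2)CC1` gives 1.8 ug/mL and compound 2 `CCCCCCCC/N=C/N1CCC(C(c2ccccc2)c2ccc(O)cc2)CC1` gives 0.96 ug/mL. Going by the values given here, the only measured step, hydroxy in place of hydrogen on an aromatic carbon, is a 1.9-fold lower number from compound 1 to compound 2 (0.27 log units; within the scatter), so compound 1 stands level with compound 2. Compound 3 `COC(=O)CCCCCCC/N=C/N1CCC(C(c2ccccc2)c2ccccc2)CC1` differs from compound 1 elsewhere: methoxycarbonyl in place of methyl on a saturated chain carbon, seven bonds along the chain from a double-bonded nitrogen. Among the compounds with values here, no measured step touches that chain, so the guidance is weak. A modest move is expected, tilted towards a higher number, as an estimated 1.6-fold higher number from compound 1 to compound 3 (0.19 log units; within the scatter). For compound 3 the expected value is 2.8 ug/mL, with an estimated range from 0.8 ug/mL to 10 ug/mL.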

Compound 3, half-maximal inhibitory concentration: 0.3 ug/mL
Compound 3: middle estimate off by 9.3-fold (0.97 log units), on the high side; measured number outside the range, below it.
By their numbers in this assay, from the lowest: compound 3; then compounds 2 and 1 (each within the scatter of the next).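

Methoxycarbonyl in place of methyl on this saturated chain carbon gives a 6.0-fold lower number from compound 1 to compound 3 (0.78 log units; beyond the scatter) in this assay, so a change on the chain can shift the number. This is the only step shown that lies beyond the scatter, and it is larger than the step on the aromatic carbon. No measurement here accounts for the drop.

Going by these compounds, it remains open whether a carboxylic acid or an amide in place of methoxycarbonyl would give a similar number. A longer chain carrying methoxycarbonyl is also untested among the compounds shown.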